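A few compounds are considered here, and "the series" means these few. Any claim that something is new, unique, unknown or untested is made for them only; others in the source may bear on it.

Compound 1 `CS(=O)(=O)c1cc(F)ccc1NCC1=NCCN1` gives < 10000 nM in a functional assay on CHO cells for agonist activity at Alpha-2C adrenergic receptor (Homo sapiens); a higher number here means that more compound is needed for the effect, a lower number that less compound is needed. Compound 2 `CC(C)S(=O)(=O)c1ccccc1NCC1=NCCN1` gives < 10000 nM. Compound 3 `CSc1c(F)cccc1NCC1=NCCN1` gives 15.9 nM.

Within this set compound 3 stands as the only numbered result; the entries for compound 1 and compound 2 are limits of this assay, not numbers, and both sit at the limit of < 10000 nM in this assay, at which 2 of the 3 values shown sit. Compound 4 `CS(=O)(=O)c1c(F)cccc1NCC1=NCCN1` is not yet measured. It differs from compound 3 by methylsulfonyl in place of methylsulfanyl on an aromatic carbon, ortho to a fluoro group. Among the measured compounds shown here, no measured pair isolates this change, and the two compounds already carrying a sulfonyl, compound 1 and compound 2, returned only limits, so the step is uncertain. A loss of potency beyond the scatter is expected, a 9.4-fold higher number from compound 3 to compound 4 (0.97 log units; beyond the scatter). Compound 4 is estimated at 150 nM, within 25 nM to 3000 nM, with a fair chance that only a limit is reported.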

Compound 4, half-maximal effective concentration: 501 nM
The estimate for compound 4 lay 3.3-fold (0.52 log units) below the measured number; low and high end bracket the measured number.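

In this assay, among the compounds shown here, methylsulfonyl in place of methylsulfanyl on an aromatic carbon, ortho to a fluoro group, gives a 32-fold higher number from compound 3 to compound 4 (1.50 log units; beyond the scatter), the first reading of this change from a measured pair. For the compounds shown here, compound 4 is also the first sulfonyl compound with a number, so at this position the change raises the number sharply but still leaves a measurable effect. Compound 1 and compound 2 remain limits, not numbers: the limit of < 10000 nM in this assay, at which 2 of the 4 values shown sit.

Open, as far as these compounds go, is how an amine or a methylsulfinyl group would read at this position. Going by these compounds alone, also open is whether the step depends on the fluoro group, which no pair here varies.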